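Swapping fluoro for chloro beside the phenol

The source may hold more compounds than are shown below. What is called first, only, known or untested is meant among the compounds shown, and "the series" means these compounds.

The shared core carries a para-chlorophenyl group on one ring nitrogen and a tert-butyl group on the ring carbon next to the other nitrogen; what varies is the aryl group on a saturated ring carbon. Compound 1 `CC(C)(C)C1=NN(c2ccc(Cl)cc2)C(c2cccc(O)c2)C1` gives 2000 nM in an assay on U-937 cells for inhibition of protein kinase C zeta type (Homo sapiens), read by reporter gene assay; a lower number here means a stronger inhibitor, a higher number a weaker inhibitor. Compound 2 `CC(C)(C)C1=NN(c2ccc(Cl)cc2)C(c2ccc(O)c(F)c2)C1` gives 3700 nM in this assay. Going by the values given here, compound 2 is one of only two measured compounds, and its number and that of compound 1 lie within the usual scatter of each other, as a 1.9-fold higher number from compound 1 to compound 2 (0.27 log units; within the scatter) shows. Compound 3 `CC(C)(C)C1=NN(c2ccc(Cl)cc2)C(c2ccc(O)c(Cl)c2)C1` differs from compound 2 by chloro in place of fluoro on an aromatic carbon. Among the compounds with values here, no measured step involves a halogen swap on this aryl ring, so nothing here bears directly on it, and the one step that exists stayed within the scatter. Compound 3 is therefore expected to give about 3500 nM, with a range from 1500 nM to 8000 nM. The estimated step of a 1.1-fold lower number from compound 2 to compound 3 (0.02 log units; within the scatter) is expected to lie within the scatter.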

Compound 3, half-maximal inhibitory concentration: 2900 nM
For compound 3 the middle estimate is 1.2-fold (0.08 log units) above the measured one; the measured number falls inside the stated range.
By their numbers in this assay, from the lowest: compounds 1, 3 and 2 (each within the scatter of the next).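

Replacing fluoro with chloro on this aromatic carbon, ortho to a hydroxy group, gives a 1.3-fold lower number from compound 2 to compound 3 (0.11 log units; within the scatter) in this assay and so stays within the scatter: at this position the two halogens cannot be told apart in this assay. Compared with the 3-hydroxyphenyl group, the 3-chloro-4-hydroxyphenyl group gives a 1.5-fold higher number from compound 1 to compound 3 (0.16 log units; within the scatter) and also stays within the scatter, so all three aryl groups shown now lie within the scatter of one another, whether the added halogen is fluoro or chloro. No evidence bears on this result, so nothing can be said about what lies behind it.

On these data alone, whether a methyl, a methoxy or a nitrile on this same aromatic carbon would shift the number beyond the scatter remains open. So does what an amine or a carboxylic acid in place of the hydroxy group would do.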